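A Methyl Added Beside Two Different Nitrogens

A few compounds are considered here, and "the series" means these few. Any claim that something is new, unique, unknown or untested is made for them only; others in the source may bear on it.

Compound 1 `CCCCc1oc2ccccc2c1C(=O)c1ccc(OCCCC(=O)NCc2ccccc2)cc1` and compound 2 `CCCCc1oc2ccccc2c1C(=O)c1ccc(OCCCC(=O)N[C@H](C)c2ccccc2)cc1` share a core and differ by methyl in place of hydrogen on a saturated chain carbon bound to an amide-type nitrogen and an aromatic carbon. In a functional assay on MCF7 cells (Homo sapiens) for antiproliferative activity, read by MTT assay, with a stated time of 24 h (a lower number here means a stronger inhibitor, a higher number a weaker inhibitor), compound 1 gives 49700 nM. For compound 2 this assay reports only a limit, > 50000 nM. The step of a number no lower from compound 1 to compound 2 (the limit leaves the size open) cannot be sized because the limit of > 50000 nM in this assay, at which 1 of the 3 values shown sits, caps what can be seen. Compound 3 `CCCCc1oc2ccccc2c1C(=O)c1cc(I)c(OCCCN2CCN(C)CC2)c(I)c1` carries another core; the difference between the two cores is not broken down here. In this assay compound 3 gives 5370 nM, well apart from compound 1. Compound 4 `CCCCc1oc2ccccc2c1C(=O)c1cc(I)c(OCCCN2CCN(CC)CC2)c(I)c1` is unmeasured and differs from compound 3 by methyl in place of hydrogen on a saturated chain carbon bound to an amine nitrogen in a ring, the same kind of change as before, though here the carbon is bound to an amine nitrogen in a ring rather than to an amide-type nitrogen and an aromatic carbon. With the earlier step left open, the expectation rests on compound 3 holding near 5370 nM, so the step of a 1.1-fold lower number from compound 3 to compound 4 (0.03 log units; within the scatter) is expected to be small. Compound 4 is estimated at 5000 nM, between 2500 nM and 12000 nM.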

Compound 4, half-maximal inhibitory concentration: 39500 nM
Estimate against measurement, compound 4: 7.9-fold (0.90 log units) below; measured number outside the range, above it.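

In this assay, the added methyl weakens the compound on the core of compound 3, with a 7.4-fold higher number from compound 3 to compound 4 (0.87 log units; beyond the scatter). Set beside the same change on the core of compound 1, this result can be neither matched nor contrasted in size: the same change on two cores in this assay, a number no lower (the limit leaves the size open) from compound 1 to compound 2 and a 7.4-fold higher number (0.87 log units; beyond the scatter) from compound 3 to compound 4; the limit leaves it open whether they differ. From the compounds shown here alone, the earlier step cannot be read, so carrying the change from one core to the other remains untested, and what caps that step is this: the limit of > 50000 nM in this assay, at which 1 of the 4 values shown sits.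

The compounds shown leave open how a longer chain, such as a propyl group in place of the ethyl of 4-ethylpiperazin-1-yl, would behave on the core of compound 3. They also leave open whether the weakening grows with chain length or stops at ethyl.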